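Methoxy to hydroxy on the saturated-ring series

The compounds below may be only part of what the source reports. "The series", "measured", "known", "first", "only" and "open" are said of these compounds alone.

In an assay on HEK293 cells for inhibition of protein kinase C zeta type (Homo sapiens), read by 33P incorporation, with a stated time of 40 min, tested at 20 uM, in the presence of a further agent that is not named here (a higher number here means more inhibition at the concentration tested (going by the name of the read-out), a lower number less inhibition), compound 1 `COc1ccc(C2=NN(c3ccc(Cl)cc3)C(c3ccc(Cl)cc3)C2)cc1` gives 23%. Compound 2 `COc1ccc(C2=NN(c3ccc(Cl)cc3)C(c3cccc(Cl)c3)C2)cc1` gives 39%, the higher of the two numbers shown. For the measured compounds named here, the only recorded step is a number 16 percentage points higher from compound 1 to compound 2 (beyond the scatter), 3-chlorophenyl in place of 4-chlorophenyl on a saturated ring carbon. Compound 3 `Oc1ccc(C2=NN(c3ccc(Cl)cc3)C(c3cccc(Cl)c3)C2)cc1` differs from compound 2 by hydrogen in place of methyl on an oxygen on an aromatic ring. No measured step touches the methoxy group, so nothing shown bears on this change, and in this assay no step beyond the scatter is expected in either direction. Compound 3 is therefore estimated at 38%, within 18% to 58%. The expected step is a number 1 percentage points lower from compound 2 to compound 3 (within the scatter).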

Compound 3, a percentage reported as inhibition, at one concentration (the size of the read-out at that concentration, not a potency): 71.8%
Estimate against measurement, compound 3: 33.8 percentage points below, and the stated range ends below it.
By their numbers in this assay, from the lowest: compound 1; then compound 2; then compound 3.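

For the compounds shown here, the 4-methoxyphenyl to 4-hydroxyphenyl change is the first measured change at this position, and in this assay it gives a number 32.8 percentage points higher from compound 2 to compound 3 (beyond the scatter). The number in this assay is therefore higher with hydrogen than with methyl on this oxygen on the 3-chlorophenyl background. No measurement shown accounts for the gain.

From the compounds shown here alone, whether the same change gives a similar step on the 4-chlorophenyl background of compound 1 remains open. So does whether an amine or a carboxylic acid at this position would hold the gain.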